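Ring nitrogen substituent in a two-compound series

This account rests on a few compounds, and the source may have more. Where it says the series, first, only, none or still open, it means among the compounds named here.

- compound 1 `O=C1CS/C(=N/Nc2nncc3ccccc23)N1c1ccccc1`: 63 nM
- compound 2 `CCN1C(=O)CS/C1=N/Nc1nncc2ccccc12`: 54 nM

In a functional assay on UO-31 cells (Homo sapiens) for antiproliferative activity, read by sulforhodamine B assay, with a stated time of 72 h (a lower number here means a stronger inhibitor, a higher number a weaker inhibitor), compound 2 gives 54 nM, level with compound 1 within the scatter. Compound 3 `O=C1CS/C(=N/Nc2nncc3ccccc23)N1` carries hydrogen in place of ethyl on an amide-type nitrogen in a ring. Going by the values given here, one measured step bears on this nitrogen: a 1.2-fold lower number from compound 1 to compound 2 (0.07 log units; within the scatter), with ethyl in place of phenyl. Among the compounds with values here, no measured compound carries the hydrogen, so this evidence is thin, and only a modest change towards a higher number is expected in this assay. For compound 3 the estimated value is 80 nM, with an expected range of 25 nM to 250 nM. This estimate means an expected 1.5-fold higher number from compound 2 to compound 3 (0.17 log units; within the scatter).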

Compound 3, half-maximal inhibitory concentration: 25 nM
Estimate against measurement, compound 3: 3.2-fold (0.51 log units) above, and the stated range covers the measured number.
By their numbers in this assay, from the lowest: compound 3; then compounds 2 and 1 (each within the scatter of the next).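

Going by these compounds alone, in the first steps at this position to lie beyond the scatter, hydrogen on the amide-type nitrogen gives a lower number than either ethyl (a 2.2-fold lower number from compound 2 to compound 3 (0.33 log units; beyond the scatter)) or phenyl (a 2.5-fold lower number from compound 1 to compound 3 (0.40 log units; beyond the scatter)) in this assay. Both steps are modest, and across these three compounds the nitrogen substituent is not needed for a low number. No evidence is available to explain this difference.

As far as these compounds go, whether methyl, a longer chain such as propyl, or a chain ending in an amine would match hydrogen on this nitrogen remains open. Changes elsewhere on the shared core also remain open.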